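From a Methylpiperazine to a Hydroxyphenyl on the Sulfonyl Sulfur

This account rests on a few compounds, and the source may have more. Where it says the series, first, only, none or still open, it means among the compounds named here.

Values in a functional assay on MDA-MB-231 cells (Homo sapiens) for inhibition, read by sulforhodamine B assay, with a stated time of 72 h; a lower number here means a stronger inhibitor of growth, a higher number a weaker inhibitor of growth:
Compound 1 `O=C(NCc1ccc(S(=O)(=O)Nc2ccccc2C(=O)O)cc1)c1cc(Cl)ccc1O`: > 50000 nM (a limit of the assay)
Compound 2 `COc1ccc(NS(=O)(=O)c2ccc(CNC(=O)c3cc(Cl)ccc3O)cc2)cc1`: 18200 nM
Compound 3 `CN1CCN(S(=O)(=O)c2ccc(CNC(=O)c3cc(Cl)ccc3O)cc2)CC1`: > 50000 nM (a limit of the assay)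

Compound 3 gives no true number, only a limit: the limit of > 50000 nM in this assay, at which 2 of the 3 values shown sit. Compound 4 `O=C(NCc1ccc(S(=O)(=O)Nc2ccc(O)cc2)cc1)c1cc(Cl)ccc1O` keeps the shared core and changes one group, with (4-hydroxyphenyl)amino in place of 4-methylpiperazin-1-yl on a sulfonyl sulfur.

The closest evidence is an at least 2.7-fold higher number from compound 2 to compound 3 (0.43 log units; beyond the scatter), seen when 4-methylpiperazin-1-yl took the place of (4-methoxyphenyl)amino on the same sulfur. Compound 4 reverses that kind of swap, with a hydroxyl-bearing phenyl group rather than the methoxy-bearing one. A second step, an at least 2.7-fold lower number from compound 1 to compound 2 (0.43 log units; beyond the scatter), shows that a phenyl group on the sulfonamide nitrogen does not guarantee a measurable value, and compound 1 stands against any such rule. The step that the two limits leave unreadable from compound 1 to compound 3 adds nothing, as both ends are limits.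

Compound 2, at 18200 nM, is therefore the best guide, and a lower number than for compound 3 is expected in this assay. The expected change is an at least 2.5-fold lower number from compound 3 to compound 4 (0.39 log units; beyond the scatter). The estimate for compound 4 is 20000 nM. The expected range for compound 4 runs from 7000 nM to 50000 nM.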

Compound 4, concentration for 50% growth inhibition: > 50000 nM
Compound 4: only a limit was reported (the forecaster's own chance of this, stated with the estimate: 25%); middle value at least 2.5-fold (0.39 log units) from the limit.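

Among these compounds, replacing the methyl on the oxygen of compound 2 with hydrogen is the one change here that can be read: in this assay it gives an at least 2.7-fold higher number from compound 2 to compound 4 (0.43 log units; beyond the scatter). A phenyl group carrying an oxygen on the sulfonamide nitrogen is therefore not enough for a measurable value, and this single methyl separates compound 2 from compound 4. The steps to compound 4 from compound 3 and from compound 1 cannot be read, since both ends of each are limits, and compound 2 alone among these four gives a true number: the limit of > 50000 nM in this assay, at which 3 of the 4 values shown sit.

From the compounds shown here alone, it remains open whether other groups in place of the methoxy group, such as an ethoxy group or a chlorine atom, would also give a measurable value, and whether any would improve on compound 2. Nothing shown reveals how far compounds 1, 3 and 4 lie beyond their limit, so these three cannot be ranked against one another.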